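The source may hold more compounds than are shown below. What is called first, only, known or untested is meant among the compounds shown, and "the series" means these compounds.

Compound 3, `CCC(c1ccc(O)c(OC)c1)c1ccccc1O`, gives 90% in a functional assay for inhibition, with a stated time of 18 h, tested at 100 ug/mL; a lower number here means less inhibition, a higher number more inhibition at the concentration tested (going by the name of the read-out). Its two measured neighbours sit close by. Compound 1, `CCC(c1ccc(O)c(OC)c1)c1cccc(O)c1O`, gives 90% in this assay, and compound 2, `CCOc1cccc(C(CC)c2ccc(O)c(OC)c2)c1O`, gives 89%. The steps among them are small: no change at the digits printed from compound 1 to compound 3 (within the scatter), a number 1 percentage points higher from compound 2 to compound 3 (within the scatter), and a number 1 percentage points lower from compound 1 to compound 2 (within the scatter). Compound 3 therefore stands level with compound 1 at the digits shown, and compound 2 lies within the scatter of both, so nothing here separates the three.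

Compound 4, `CCC(c1ccc(O)c(OC)c1)c1ccc(O)cc1O`, differs from compound 3 in one place: hydroxy in place of hydrogen on an aromatic carbon. Going by the values given here, the step that bears most directly on this is the one from compound 1 to compound 3, in which a hydroxy on an aromatic carbon left without any change in this assay. The step from compound 1 to compound 2 and the step from compound 2 to compound 3 also stayed within the scatter. Adding a hydroxy on an aromatic carbon is thus expected to move the number little, if at all, so the expected step is a number 1 percentage points lower from compound 3 to compound 4 (within the scatter). Compound 4 is estimated to give 89% in this assay, within a range from 80% to 96%.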

Compound 4, a percentage reported as inhibition, at one concentration (the size of the read-out at that concentration, not a potency): 85%
For compound 4 the middle estimate is 4 percentage points above the measured one; measured number inside the range.
By their numbers in this assay, from the lowest: compounds 4, 2, 1 and 3 (each within the scatter of the next).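

In this assay, hydroxy in place of hydrogen at this position, on an aromatic carbon meta to a hydroxy group and para to a large group, gives a number 5 percentage points lower from compound 3 to compound 4 (within the scatter) and so leaves the read-out inside the usual scatter. Going by these compounds alone, the earlier steps changed the ring at a different place, so this is the first reading at this position, and it shows that the position accepts a hydroxy with no change that can be told apart from the scatter of the assay. Nothing at hand bears on why the step takes the size it does.

The compounds shown leave open whether a carboxylic acid, an amine or a longer chain at this position would also leave the number within the scatter. They also leave open whether the four compounds, which a single test concentration does not separate, would give different numbers at another concentration.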